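The source may hold more compounds than are shown below. What is called first, only, known or untested is meant among the compounds shown, and "the series" means these compounds.

Measured so far in a functional assay for agonist activity at growth hormone secretagogue receptor type 1 (Homo sapiens), read by FLIPR; on this read-out higher numbers stand for an effect only at larger amounts of compound and lower numbers for an effect already at smaller amounts:
- compound 1 `COc1ccc(N2C[C@@H](C)N[C@@H](C)C2)cc1NS(=O)(=O)c1ccc(-c2cnco2)s1`: 2.51 nM
- compound 2 `COc1ccc(N2C[C@@H](C)N[C@@H](C)C2)cc1NS(=O)(=O)c1ccc(-c2ccncc2)cc1`: 316 nM
- compound 3 `COc1ccc(N2C[C@@H](C)N[C@@H](C)C2)cc1NS(=O)(=O)c1ccc(-c2cncnc2)cc1`: 316 nM

Compound 3 stands level with compound 2; together they give the highest numbers of the three, and the value of compound 1 lies far below both. The step to compound 4 `COc1ccc(N2C[C@@H](C)N[C@@H](C)C2)cc1NS(=O)(=O)c1ccc(-c2cccs2)cc1` is thiophen-2-yl in place of pyrimidin-5-yl on an aromatic carbon, placed on an aromatic carbon of a six-membered aromatic ring of carbon only, para to a large group. Among the compounds with values here, only one measured step touches this position: no change at the digits printed from compound 2 to compound 3 (within the scatter), which shows that exchanging one six-membered ring with nitrogen for another left the number unchanged. Within the data shown here, no measured step swaps a six-membered ring here for a five-membered one, so the direction of the change is open; compound 1 shows that a compound can reach a much lower number, but its structure differs at more than this one place. The step of a 2.0-fold lower number from compound 3 to compound 4 (0.30 log units; within the scatter) is therefore expected to be small and uncertain. For compound 4 the estimate is 160 nM, with a range from 40 nM to 800 nM.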

Compound 4, half-maximal effective concentration: 3.98 nM
Beside the measured number, compound 4's estimate is 40-fold (1.60 log units) above it; the measured number lies below the stated range.
By their numbers in this assay, from the lowest: compounds 1 and 4 (each within the scatter of the next); then compounds 2 and 3 (each within the scatter of the next).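

In this assay, this position, on an aromatic carbon of a six-membered aromatic ring of carbon only, proves highly sensitive to which ring it carries. Thiophen-2-yl gives a 79-fold lower number from compound 3 to compound 4 (1.90 log units; beyond the scatter) and a 79-fold lower number from compound 2 to compound 4 (1.90 log units; beyond the scatter) as a large change, whereas exchanging one six-membered ring with nitrogen for another gave no change at the digits printed from compound 2 to compound 3 (within the scatter) and so had hinted at nothing of this size. No outside data bear on why the number falls so far.

Thiophen-2-yl differs from both six-membered rings in ring size, in its sulfur and in having no ring nitrogen, so the compounds shown leave open which of these differences goes with the lower number. A phenyl or a furan-2-yl group at this position would help pull these differences apart.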